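Compound 3 to compound 4: ethyl in place of hydrogen

The source may report more compounds than this note shows. Statements on the series, on what has been measured and on what is new or still open speak of the compounds shown alone.

Among the measured compounds shown here, in a functional assay on the whole organism for antagonist activity, with Mus musculus as the target (on this read-out lower numbers stand for an effect already at smaller amounts and higher numbers for an effect only at larger amounts of compound), compound 3 `CC(=O)N(c1ccccc1)C1CCCC1N(C)C` gives 9 mg/kg and stands level with compound 1 `CCC(=O)N(c1ccc(Cl)c(Cl)c1)C1CCCC1O` at 9 mg/kg on the numbers so far. Compound 2 `CN(C)C1CCCC1N(C=O)c1ccccc1` reads > 50 mg/kg as a limit of the assay.

Compound 4 `CCCC(=O)N(c1ccccc1)C1CCCC1N(C)C` has ethyl in place of hydrogen on a saturated chain carbon bound to a carbonyl carbon and otherwise matches compound 3. For the measured compounds named here, one measured step bears on this change. Methyl in place of hydrogen on a carbonyl carbon gave an at least 5.5-fold lower number from compound 2 to compound 3 (0.74 log units; beyond the scatter) and lies beyond the scatter. From the compounds shown here alone, that step starts from a limit, so its full size remains open, and it does not show what a further extension of the same chain does. No firm direction can be assigned, and no change beyond the scatter is expected. The expected step is a 1.3-fold higher number from compound 3 to compound 4 (0.12 log units; within the scatter) in this assay on this estimate. The estimated value for compound 4 is 12 mg/kg with an expected range from 4 mg/kg to 40 mg/kg for repeated measurements.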

Compound 4, dose for half-maximal effect: 10 mg/kg
Compound 4: the middle estimate sits 1.2-fold (0.08 log units) above what was measured; the measured number falls inside the stated range.
By their numbers in this assay, from the lowest: compounds 1, 3 and 4 (each within the scatter of the next). At a limit, above all of these: compound 2.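

In this assay, ethyl in place of hydrogen on a saturated chain carbon bound to a carbonyl carbon gives a 1.1-fold higher number from compound 3 to compound 4 (0.05 log units; within the scatter), so the propylcarbonyl group of compound 4 is tolerated here as well as the acetyl group of compound 3. The longer chain on the carbonyl carbon gives an at least 5.0-fold lower number from compound 2 to compound 4 (0.69 log units; beyond the scatter), which makes a second step beyond the scatter alongside an at least 5.5-fold lower number from compound 2 to compound 3 (0.74 log units; beyond the scatter). The full size of both steps stays open because compound 2 reads as a limit: the limit of > 50 mg/kg in this assay, at which 1 of the 4 values shown sits.

From the compounds shown here alone, whether a longer chain such as butyl or a branched chain such as isopropyl would read the same at this place remains open. The read-out with an amine or a carboxylic acid on this chain is also unknown.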